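Para substituent swap in a glucokinase regulatory protein series

This account rests on a few compounds, and the source may have more. Where it says the series, first, only, none or still open, it means among the compounds named here.

Measured compounds:
compound 1 `CC#C[C@H]1CN(S(=O)(=O)c2ccc(N)nc2)CCN1c1ccc(S(=O)(=NC)C(F)(F)F)cc1` 2060 nM
compound 2 `CC#C[C@H]1CN(S(=O)(=O)c2ccc(N)nc2)CCN1c1ccc(C(O)(COC)C(F)(F)F)cc1` 202 nM
compound 3 `CC#C[C@H]1CN(S(=O)(=O)c2ccc(N)nc2)CCN1c1ccc(S(=O)(=O)NCC2CC2)cc1` 271 nM

In an assay on cells (Hepatocyte) for inhibition of glucokinase regulatory protein (Mus musculus), with stated times of 20 min and 40 min (on this read-out lower numbers stand for an effect already at smaller amounts and higher numbers for an effect only at larger amounts of compound), compound 3 sits second highest of the three numbers, within the scatter of compound 2 and well apart from compound 1, as the step of a 7.6-fold lower number from compound 1 to compound 3 (0.88 log units; beyond the scatter) shows. Compound 4 `CC#CCC(O)(c1ccc(N2CCN(S(=O)(=O)c3ccc(N)nc3)C[C@@H]2C#CC)cc1)C(F)(F)F` arises from compound 3 by a group of 10 heavy atoms (6 carbon, 1 oxygen, 3 fluorine; no ring) in place of a group of 8 heavy atoms (4 carbon, 1 nitrogen, 2 oxygen, 1 sulfur; one three-membered non-aromatic ring of carbon only), on an aromatic carbon. Among the compounds with values here, no measured step covers this exact change; the nearest guide is compound 2, whose para group is also a trifluoromethyl-bearing tertiary alcohol and which stands within the scatter of compound 3 (a 1.3-fold higher number from compound 2 to compound 3 (0.13 log units; within the scatter)). Within the data shown here, only the steps from compound 1 (a 10-fold lower number from compound 1 to compound 2 (1.01 log units; beyond the scatter)) were large. The step for compound 4 in this assay is therefore expected to be small, a 1.2-fold lower number from compound 3 to compound 4 (0.07 log units; within the scatter), with no clear direction. Compound 4 is estimated at 230 nM, range 80 nM to 650 nM.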

Compound 4, half-maximal effective concentration: 137 nM
Compound 4: the middle estimate sits 1.7-fold (0.23 log units) above what was measured; measured number inside the range.
By their numbers in this assay, from the lowest: compounds 4, 2 and 3 (each within the scatter of the next); then compound 1.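

In this assay, the step of a 1.5-fold lower number from compound 2 to compound 4 (0.17 log units; within the scatter) shows that prop-1-yn-1-yl can stand in place of methoxy on the alcohol side chain without a shift beyond the scatter. The step of a 2.0-fold lower number from compound 3 to compound 4 (0.30 log units; within the scatter) also stays within the scatter, so this position accepts both the (cyclopropylmethyl)sulfamoyl group and the alcohol group of compound 4 at similar values. Only the group of compound 1 stands apart, and the step of a 15-fold lower number from compound 1 to compound 4 (1.18 log units; beyond the scatter) is the widest in the set.

Nothing given here accounts for the gap between compound 1 and the other compounds. From the compounds shown here alone, whether an amine or a carboxylic acid would fit at this position remains open.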